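Swapping the side group on the ring carbon of compound 3

The compounds below may be only part of what the source reports. "The series", "measured", "known", "first", "only" and "open" are said of these compounds alone.

In a functional assay (brain) for inhibition, with Rattus norvegicus as the target (a lower number here means a stronger inhibitor, a higher number a weaker inhibitor), compound 1 `CCCCCCCCCCCCOC1=C(O)OC(C(O)CO)C1=O` gives 54000 nM, compound 2 `CCCCCCCCCCCCCOC1=C(O)OC(C(O)CO)C1=O` gives 7400 nM and compound 3 `CCCCCCCCCCCCCCCCCCOC1=C(O)OC(C2COC(C)(C)O2)C1=O` gives 2400 nM. Compound 3 has the lowest of the three numbers, beyond the scatter from both others.

Compound 4 `CCCCCCCCCCCCCCCCCCOC1=C(O)OC(C(O)COC(C)=O)C1=O` differs from compound 3 as follows: 2-acetoxy-1-hydroxyethyl in place of 2,2-dimethyl-1,3-dioxolan-4-yl on a saturated ring carbon. In short, 2-acetoxy-1-hydroxyethyl stands in place of 2,2-dimethyl-1,3-dioxolan-4-yl on a saturated ring carbon.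

Among the measured compounds shown here, the only measured step is a 7.3-fold lower number from compound 1 to compound 2 (0.86 log units; beyond the scatter). It is a modest change on the chain, a methyl in place of hydrogen, and not at this ring carbon, so it offers no direct guide to the size or direction of this change. For the measured compounds named here, no measured pair isolates this swap.

The expected change in this assay is a 1.3-fold higher number from compound 3 to compound 4 (0.10 log units; within the scatter), a small move with only a loosely held direction. The range is kept wide enough to reach the level of compound 2 at 7400 nM. For compound 4 the estimated value is 3000 nM, with an expected range of 900 nM to 9000 nM.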

Compound 4, half-maximal inhibitory concentration: 4200 nM
Estimate against measurement, compound 4: 1.4-fold (0.15 log units) below; low and high end bracket the measured number.
By their numbers in this assay, from the lowest: compounds 3, 4 and 2 (each within the scatter of the next, the first and the last beyond it); then compound 1.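

In this assay the swap at this saturated ring carbon, 2-acetoxy-1-hydroxyethyl in place of 2,2-dimethyl-1,3-dioxolan-4-yl, gives a 1.8-fold higher number from compound 3 to compound 4 (0.24 log units; within the scatter) and so shows the first effect read at this position rather than on the chain. With the heavy-atom count unchanged, the five-membered ring of the side group can be given up and a hydrogen-bond donor brought in without the reading leaving the scatter, at least on the chain shared by compound 3 and compound 4. No measurement on hand speaks to the reason for this result.

The swap changes the ring, the hydroxy and the acetoxy together, so the part each plays stays unresolved. From the compounds shown here alone, how a carboxylic acid or an amine on this ring carbon would read remains open.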